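Working notes: from compound 2 to compound 4

The compounds below may be only part of what the source reports. "The series", "measured", "known", "first", "only" and "open" are said of these compounds alone.

Measured so far:
compound 1 `C=C(C)C(=O)NC(=O)NC1=CS(=O)(=O)O[C@@]12[C@@H](CO[Si](C)(C)C(C)(C)C)O[C@@H](n1cc(C)c(=O)n(C)c1=O)[C@@H]2O[Si](C)(C)C(C)(C)C`: 1200 nM
compound 2 `COC(=O)NC1=CS(=O)(=O)O[C@@]12[C@@H](CO[Si](C)(C)C(C)(C)C)O[C@@H](n1cc(C)c(=O)n(C)c1=O)[C@@H]2O[Si](C)(C)C(C)(C)C`: 30700 nM
compound 3 `Cc1cn([C@@H]2O[C@@H]3COC4(O)CS(=O)(=O)O[C@@]34[C@H]2O[Si](C)(C)C(C)(C)C)c(=O)[nH]c1=O`: 100000 nM

In a functional assay on CCRF-CEM cells (Homo sapiens) (on this read-out higher numbers stand for lower toxicity in this test and lower numbers for higher toxicity in this test), compound 2 stands second highest of the three numbers, compound 3 giving a higher number and compound 1 a lower one. Compound 4 `COC(=O)CCNC1=CS(=O)(=O)O[C@@]12[C@@H](CO[Si](C)(C)C(C)(C)C)O[C@@H](n1cc(C)c(=O)n(C)c1=O)[C@@H]2O[Si](C)(C)C(C)(C)C` differs from compound 2 in one place: 2-(methoxycarbonyl)ethyl in place of methoxycarbonyl on an amine nitrogen. For the measured compounds named here, no measured step changes the group on the amine nitrogen in this way. Going by the values given here, the only single-point step, a 26-fold higher number from compound 1 to compound 2 (1.41 log units; beyond the scatter), sits on a carbonyl carbon and shows that what hangs on this nitrogen can move the number a long way. Without a closer precedent, only a moderate shift is expected, the step of a 1.5-fold lower number from compound 2 to compound 4 (0.19 log units; within the scatter) carrying wide uncertainty. Compound 4 is estimated at 20000 nM, between 5000 nM and 80000 nM.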

Compound 4, half-maximal cytotoxic concentration: > 250000 nM
Compound 4 gave a limit, no number; the forecaster's own chance of this, stated with the estimate: 15%; middle value at least 12-fold (1.09 log units) from the limit.
By their numbers in this assay, from the lowest: compound 1; then compound 2; then compound 3. At a limit, above all of these: compound 4.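

In this assay compound 4 gives > 250000 nM, which is a limit and not a number. Putting 2-(methoxycarbonyl)ethyl in place of methoxycarbonyl on the amine nitrogen gives an at least 8.1-fold higher number from compound 2 to compound 4 (0.91 log units; beyond the scatter), so a change with unchanged donor and acceptor counts still moves the read-out beyond the scatter. The range reached on this nitrogen now extends to an at least 200-fold higher number from compound 1 to compound 4 (2.31 log units; beyond the scatter), wider than the earlier step showed.

On these data alone, whether a carboxylic acid in place of the methyl ester, or a longer chain, would change the read-out stays open. The true size of both new steps also stays open: the limit of > 250000 nM in this assay, at which 1 of the 4 values shown sits.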